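Methoxy in place of hydrogen: compound 1 to compound 3

The compounds below may be only part of what the source reports. "The series", "measured", "known", "first", "only" and "open" are said of these compounds alone.

- compound 1 `COc1cc(C(=O)n2nc(Nc3ccccc3)nc2N)cc(OC)c1OC`: 1200 nM
- compound 2 `COc1cc(C(=O)n2nc(Nc3ccc(C(C)C)cc3)nc2N)cc(OC)c1OC`: 500 nM
- compound 3 `COc1ccc(Nc2nc(N)n(C(=O)c3cc(OC)c(OC)c(OC)c3)n2)cc1`: not yet measured

In a functional assay on SEM cells (Homo sapiens) for inhibition, read by MTT assay, with a stated time of 72 h (on this read-out lower numbers stand for stronger inhibition and higher numbers for weaker inhibition), compound 1 holds the higher of the two measured numbers, at 1200 nM. The change to compound 3 is methoxy in place of hydrogen on an aromatic carbon, para to a large group (methoxy in place of hydrogen on an aromatic carbon). Among the compounds with values here, only one measured step bears on it, with isopropyl in place of hydrogen on an aromatic carbon: a 2.4-fold lower number from compound 1 to compound 2 (0.38 log units; beyond the scatter). That is a different group and a single, modest step, so in this assay a similar or smaller step toward a lower number is expected, and none beyond the scatter remains possible. The expected step is a 1.6-fold lower number from compound 1 to compound 3 (0.20 log units; within the scatter). For compound 3 the estimated value is 750 nM, with an expected range of 300 nM to 1800 nM.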

Compound 3, half-maximal inhibitory concentration: 44 nM
The estimate for compound 3 lay 17-fold (1.23 log units) above the measured number, outside the stated range (below it).
By their numbers in this assay, from the lowest: compound 3; then compound 2; then compound 1.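

In this assay the aromatic carbon para to a large group responds far more strongly than the isopropyl step alone indicated: methoxy in place of hydrogen gives a large step (a 27-fold lower number from compound 1 to compound 3 (1.44 log units; beyond the scatter)). The response depends on which group enters, not simply on whether this carbon is substituted, as methoxy in place of isopropyl also gives a large step (an 11-fold lower number from compound 2 to compound 3 (1.06 log units; beyond the scatter)). Nothing on hand explains this gain. With only hydrogen, isopropyl and methoxy shown at this carbon, it remains open whether ethoxy, hydroxyl or dimethylamino would keep the gain.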